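Methylsulfanyl to ethylsulfanyl on the triazole amide series

This account rests on a few compounds, and the source may have more. Where it says the series, first, only, none or still open, it means among the compounds named here.

Three compounds share one core and differ only in the acyl group on the amide nitrogen. Compound 1 `CSc1nnc(COc2ccccc2C2=NOC(c3ccc(Cl)cc3Cl)C2)n1NC(=O)CCl` gives 2.7 ug/mL in an ADME assay (MDM cells, Homo sapiens) for cytotoxicity, read by resazurin assay, with a stated time of 3 days; on this read-out higher numbers stand for weaker inhibition and lower numbers for stronger inhibition. Compound 2 `CSc1nnc(COc2ccccc2C2=NOC(c3ccc(Cl)cc3Cl)C2)n1NC(C)=O` gives 2.7 ug/mL, and compound 3 `CSc1nnc(COc2ccccc2C2=NOC(c3ccc(Cl)cc3Cl)C2)n1NC(=O)c1ccccc1` gives 2.2 ug/mL. Compound 3 thus carries the smallest of the three numbers, but the step of a 1.2-fold lower number from compound 1 to compound 3 (0.09 log units; within the scatter) and the step of a 1.2-fold lower number from compound 2 to compound 3 (0.09 log units; within the scatter) both lie within the scatter, as does the step of no change at the digits printed from compound 1 to compound 2 (within the scatter). Across the acyl changes seen so far, the read-out has not moved beyond the scatter at all.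

Compound 4 `CCSc1nnc(COc2ccccc2C2=NOC(c3ccc(Cl)cc3Cl)C2)n1NC(=O)c1ccccc1` is not yet measured. It differs from compound 3 by methyl in place of hydrogen on a saturated chain carbon bound to a sulfur. Within the data shown here, no measured step touches this part of the structure: every step so far sits on the carbonyl carbon, and all were within the scatter. There is therefore no basis for expecting movement in either direction, and the estimate for compound 4 is taken at the number of compound 3, with a range wide enough to cover the usual repeat variation. For compound 4 the expected step is no change at the digits printed from compound 3 to compound 4 (within the scatter). The estimated value for compound 4 is 2.2 ug/mL, expected to fall between 1.1 ug/mL and 4.4 ug/mL.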

Compound 4, half-maximal inhibitory concentration: 1.8 ug/mL
Compound 4: middle estimate off by 1.2-fold (0.09 log units), on the high side; measured number inside the range.
By their numbers in this assay, from the lowest: compounds 4, 3, 1 and 2 (each within the scatter of the next).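

Methylsulfanyl to ethylsulfanyl is the only step here on a saturated chain carbon bound to a sulfur, whereas the earlier steps all sat on a carbonyl carbon. In this assay, this step reads as a 1.2-fold lower number from compound 3 to compound 4 (0.09 log units; within the scatter), so adding one methyl at this position leaves the read-out within the scatter, at least with the benzoyl amide of compound 3. Compound 4 therefore extends the flat picture to a second place on the structure, with all four compounds in an unbroken run where each lies within the scatter of the next, and nothing available explains this flat result.

Whether a longer chain such as butyl on the sulfur, or an amine in place of the methylsulfanyl group, would take the read-out beyond the scatter remains open, as a single added methyl is the only change shown at this position. Also open, on these data alone, is whether methylsulfanyl to ethylsulfanyl reads the same with the chloroacetyl amide of compound 1 or the acetyl amide of compound 2.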